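The compounds below may be only part of what the source reports. "The series", "measured", "known", "first", "only" and "open" are said of these compounds alone.

Three hydrazones built on the same core have been tested in an ADME assay on HEL cells (Homo sapiens) for cytotoxicity; a lower number here means that less compound is tolerated, a higher number that more compound is tolerated. Compound 1 `O=C(COc1cccc2ccccc12)N/N=C/c1ccc(O)cc1` gives 60.6 ug/mL, compound 2 `O=C(COc1cccc2ccccc12)N/N=C/c1ccccc1Br` gives 100 ug/mL, and compound 3 `O=C(COc1cccc2ccccc12)N/N=C/C=C/c1ccccc1` gives 100 ug/mL. Compound 3 thus stands level with compound 2 at the top of the three numbers, and the step of a 1.7-fold higher number from compound 1 to compound 3 (0.22 log units; within the scatter) is within the scatter, as is no change at the digits printed from compound 2 to compound 3 (within the scatter) and a 1.7-fold higher number from compound 1 to compound 2 (0.22 log units; within the scatter).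

Compound 4 `O=C(COc1cccc2ccccc12)N/N=C/c1ccccc1O` differs from compound 3 in one place: 2-hydroxyphenyl in place of 2-phenylethenyl on a carbon with a double bond to nitrogen. Within the data shown here, two measured steps bear on this. The step of no change at the digits printed from compound 2 to compound 3 (within the scatter) shows that swapping one group on that carbon for another left the number unchanged, and the step of a 1.7-fold higher number from compound 1 to compound 3 (0.22 log units; within the scatter) shows that a hydroxyphenyl group there, compared with the phenylethenyl group, gave only a small and not meaningful difference. Compound 4 also carries a hydroxyphenyl group, so a step of about a 1.3-fold lower number from compound 3 to compound 4 (0.10 log units; within the scatter) in this assay is expected, which is no change beyond the scatter. Compound 4 is therefore estimated at 80 ug/mL, with a range from 45 ug/mL to 110 ug/mL.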

Compound 4, half-maximal cytotoxic concentration: 3.57 ug/mL
Compound 4: the middle estimate sits 22-fold (1.35 log units) above what was measured; measured number outside the range, below it.
By their numbers in this assay, from the lowest: compound 4; then compounds 1, 2 and 3 (each within the scatter of the next).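

In this assay, among these compounds, the group on the carbon with a double bond to nitrogen proves able to shift the number strongly, which the earlier compounds did not show: 2-hydroxyphenyl in place of 2-phenylethenyl gives a 28-fold lower number from compound 3 to compound 4 (1.45 log units; beyond the scatter), and hydroxy in place of bromo on an aromatic carbon gives a 28-fold lower number from compound 2 to compound 4 (1.45 log units; beyond the scatter). Simply carrying a hydroxy group is not enough to produce this, as 2-hydroxyphenyl in place of 4-hydroxyphenyl still gives a 17-fold lower number from compound 1 to compound 4 (1.23 log units; beyond the scatter), so among these compounds it matters where the hydroxy group sits on the phenyl ring. Nothing measured here explains this large drop.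

Going by these compounds, it remains open whether the drop is specific to the hydroxy group, as a methoxy group or an amine on the same aromatic carbon could show. The compounds shown also leave open whether the same drop would appear with a different group in place of the naphthyl-bearing part of the shared core.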